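Same Ring Nitrogen Group, Different Substituent on the Phenyl

The source may report more compounds than this note shows. Statements on the series, on what has been measured and on what is new or still open speak of the compounds shown alone.

Compound 1 `CC(C)(C)OC(=O)N1CCC(c2nc(COc3ccc(/C=C4\CC(=O)NC4=O)cc3F)cs2)CC1` was tested in a functional assay on cells for agonist activity at Glucose-dependent insulinotropic receptor (Homo sapiens), read by a luciferase reporter, with a stated time of 6 h (a higher number here means that more compound is needed for the effect, a lower number that less compound is needed), and gives 157 nM. Compound 2 `Cc1cc(/C=C2\CC(=O)NC2=O)ccc1OCc1csc(C2CCN(CC(C)(C)O)CC2)n1` shares much of this build but carries another group on the ring nitrogen; in this assay compound 2 gives "not determined" (no result reported), so it stands nowhere on the numbers and offers no anchor of its own. Compound 3 `Cc1cc(/C=C2\CC(=O)NC2=O)ccc1OCc1csc(C2CCN(C(=O)OC(C)(C)C)CC2)n1` is the compound of interest: tert-butoxycarbonyl in place of 2-hydroxy-2-methylpropyl on an amine nitrogen in a ring. With no number for compound 2, no size or direction for the step from compound 2 to compound 3 can be read in this assay. The closest guide is compound 1, whose ring nitrogen also bears tert-butoxycarbonyl and which in this assay gives 157 nM, the two differing only in the small group on the phenyl ring. Compound 3 is expected to give about 150 nM in this assay, with a plausible range from 50 nM to 500 nM.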

Compound 3, half-maximal effective concentration: 19 nM
Compound 3: middle estimate off by 7.9-fold (0.90 log units), on the high side; the measured number lies below the stated range.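

With tert-butoxycarbonyl kept on the ring nitrogen, methyl in place of fluoro on an aromatic carbon proves to be far from a neutral swap: in this assay it gives an 8.3-fold lower number from compound 1 to compound 3 (0.92 log units; beyond the scatter). This small change on the phenyl ring is therefore enough on its own to move the number clearly, and of the two groups seen at this place, methyl gives the lower number. No supporting data explain why this swap lowers the number.

As far as these compounds go, the step from compound 2 to compound 3 cannot be read, so the effect of exchanging 2-hydroxy-2-methylpropyl for tert-butoxycarbonyl on the ring nitrogen remains unknown. From the compounds shown here alone, whether chloro or methoxy on the same aromatic carbon would give a number closer to that of methyl or of fluoro also remains open.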